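The source may report more compounds than this note shows. Statements on the series, on what has been measured and on what is new or still open speak of the compounds shown alone.

Measured compounds:
compound 1 `Nc1scc(CN2CCN(c3ccccc3)CC2)c1C(=O)c1ccc(Cl)cc1`, 1 nM
compound 2 `Nc1scc(CN2CCN(c3ccc(Cl)cc3)CC2)c1C(=O)c1ccc(Cl)cc1`, 1.1 nM
compound 3 `Nc1scc(CN2CCN(c3ccc(C(F)(F)F)cc3)CC2)c1C(=O)c1ccc(Cl)cc1`, 1 nM

In an assay on CHO cells for displacement of a labelled ligand from adenosine receptor A1 (Homo sapiens) (on this read-out higher numbers stand for weaker binding and lower numbers for tighter binding), compound 1 stands level with compound 3 and shares the lowest number of the three, with compound 2 giving a number that differs from it only within the scatter. The three measured steps all concern the aromatic ring on the piperazine nitrogen: a 1.1-fold higher number from compound 1 to compound 2 (0.04 log units; within the scatter), no change at the digits printed from compound 1 to compound 3 (within the scatter) and a 1.1-fold lower number from compound 2 to compound 3 (0.04 log units; within the scatter). None of them moved the number beyond the scatter.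

Compound 4 `Nc1scc(CN2CCN(c3ccccn3)CC2)c1C(=O)c1ccc(Cl)cc1` is reached from compound 1 by pyridin-2-yl in place of phenyl on an amine nitrogen in a ring. Among the compounds with values here, no measured step exchanges the ring itself, so the bearing of the data is indirect: the substituent changes on that ring were all flat, which suggests that this position tolerates variation without a shift in this assay. An exchange of the ring for one with a hetero atom is a different kind of change, and a modest rise in the number cannot be excluded. Compound 4 is therefore expected to give 1.6 nM in this assay, within a range of 0.5 nM to 6 nM, a step of a 1.6-fold higher number from compound 1 to compound 4 (0.20 log units; within the scatter) that is expected to stay near the scatter.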

Compound 4, dissociation constant: 1.2 nM
For compound 4 the middle estimate is 1.3-fold (0.12 log units) above the measured one; low and high end bracket the measured number.
By their numbers in this assay, from the lowest: compounds 1, 3, 2 and 4 (each within the scatter of the next).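

Where the earlier compounds varied only the substituent on the phenyl ring, compound 4 exchanges the ring itself for pyridin-2-yl, and in this assay this gives a 1.2-fold higher number from compound 1 to compound 4 (0.08 log units; within the scatter). Set against the substituted rings, the picture is the same, with a 1.2-fold higher number from compound 3 to compound 4 (0.08 log units; within the scatter) and a 1.1-fold higher number from compound 2 to compound 4 (0.04 log units; within the scatter), so a ring with one hetero atom and one hydrogen-bond acceptor at this place on the piperazine stands level within the scatter with all three phenyl compounds. Nothing available explains why the number holds across this exchange.

The compounds shown leave open whether this tolerance extends to a saturated ring such as cyclohexyl, or to a benzyl group on the same ring nitrogen. They also leave open how a carboxylic acid or an amine on the pyridin-2-yl ring would read in this assay.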